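Removal of the ring methoxy from the nitrile analogue

This account rests on a few compounds, and the source may have more. Where it says the series, first, only, none or still open, it means among the compounds named here.

Compound 2 `COc1cccc(C(=O)CC2C(C#N)=C(N)Oc3c(OC)cc(Br)cc32)c1` carries a nitrile on the double-bonded ring carbon and in a functional assay on MCF7 cells (Homo sapiens) for antiproliferative activity, read by sulforhodamine B assay, with a stated time of 72 h, tested at 10 uM (on this read-out lower numbers stand for a stronger effect and higher numbers for a weaker effect at the one concentration tested), compound 2 gives 55.9%. Compound 1 `COC(=O)C1=C(N)Oc2c(OC)cc(Br)cc2C1CC(=O)c1cccc(OC)c1`, the methoxycarbonyl counterpart, gives 142% in this assay. On these two numbers compound 2 stands lowest. Among the measured compounds shown here, the one measured step, a number 86.1 percentage points lower from compound 1 to compound 2 (beyond the scatter), concerns cyano in place of methoxycarbonyl on a double-bonded ring carbon and leaves the aromatic ring untouched.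

Compound 3 `COc1cccc(C(=O)CC2C(C#N)=C(N)Oc3ccc(Br)cc32)c1` differs from compound 2 by hydrogen in place of methoxy on an aromatic carbon. For the measured compounds named here, no measured step in this assay involves a change on the aromatic ring, so the numbers give neither size nor direction for this replacement; the large step from the double-bonded ring carbon does not bear on it. A step within the scatter is therefore expected, with a wide range to cover the lack of any comparable pair.

In this assay compound 3 is expected to give 60%, within 35% to 90%. The expected step is a number 4.1 percentage points higher from compound 2 to compound 3 (within the scatter).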

Compound 3, a percentage reported as activity, at one concentration (the size of the read-out at that concentration, not a potency): 51.2%
Estimate against measurement, compound 3: 8.8 percentage points above, within the range that was stated.
By their numbers in this assay, from the lowest: compounds 3 and 2 (each within the scatter of the next); then compound 1.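

Hydrogen in place of methoxy on this aromatic carbon, ortho to a fused ring and meta to a bromo group, gives in this assay a number 4.7 percentage points lower from compound 2 to compound 3 (within the scatter); with the nitrile kept, the read-out at the one concentration tested therefore does not separate the methoxy and hydrogen forms. Among the compounds shown here, this is the first measured change on the aromatic ring, and the step on the double-bonded ring carbon, a number 86.1 percentage points lower from compound 1 to compound 2 (beyond the scatter), remains the only one beyond the scatter. No evidence is at hand that would account for either step.

Open, on these data alone, is whether this aromatic carbon tolerates groups other than methoxy and hydrogen, such as an amine, a carboxylic acid or a longer chain like ethoxy, and whether the same replacement in the methoxycarbonyl compound would track the nitrile pair. Also open, as far as these compounds go, is how far the bromo group and the methoxy on the other aromatic ring contribute, since both stay the same in all three compounds.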